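A Smaller Ring in Place of Piperidine on Compound 1

The compounds below may be only part of what the source reports. "The series", "measured", "known", "first", "only" and "open" are said of these compounds alone.

Of the compounds shown here, three have been measured so far in an ADME assay on a cell-free system (plasma, Homo sapiens); on this read-out higher numbers stand for a larger free fraction and lower numbers for a smaller free fraction. Compound 1 `CC(=O)Nc1cc(-c2ccc(N(C)C(=O)c3c(F)cccc3Cl)c(N3CCCCC3)c2)n(C(C)C)n1` gives 0.004, the lowest of the three numbers. Compound 3 `CC(C)n1nc(C(N)=O)cc1-c1ccc(N(C)C(=O)c2c(F)cccc2Cl)c(OCC(F)(F)F)c1` gives 0.059 in this assay, and compound 2 `CC(=O)Nc1cc(-c2cnc(N(C)C(=O)c3c(F)cccc3Cl)c(N3CCCCC3)c2)n(C(C)C)n1` gives 0.076; each of these stands above compound 1 by a gap that is beyond the usual scatter of repeated measurements, so compound 1 has the smallest free fraction of the three.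

Compound 4 `CC(=O)Nc1cc(-c2ccc(N(C)C(=O)c3c(F)cccc3Cl)c(N3CCCC3)c2)n(C(C)C)n1` has not yet been measured. It differs from compound 1 in one place: pyrrolidin-1-yl in place of piperidin-1-yl on an aromatic carbon. For the measured compounds named here, no pair of measured compounds shows exactly this change, so nothing measured tells how large its effect is. Removing one carbon from a saturated ring while leaving everything else unchanged is the kind of change that, judged against compounds 2 and 3, which alter other parts of the molecule and move the number much further, seems unlikely to produce a large shift in this assay. Compound 4 is therefore expected to give about 0.006 in this assay, within a range from 0.003 to 0.012. That expectation amounts to a step of a 1.5-fold higher number from compound 1 to compound 4 (0.18 log units; within the scatter), a move upward that would stay within the scatter.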

Compound 4, unbound fraction in the plasma assay: 0.017
Compound 4: middle estimate off by 2.8-fold (0.45 log units), on the low side, outside the stated range (above it).
By their numbers in the plasma assay, from the lowest: compound 1; then compound 4; then compounds 3 and 2 (each within the scatter of the next).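

In the plasma assay, the swap of piperidin-1-yl for pyrrolidin-1-yl on the aromatic carbon gives a 4.3-fold higher number from compound 1 to compound 4 (0.63 log units; beyond the scatter), so this position responds even to a small edit: the ring loses a single carbon, while the counts of hydrogen-bond donors and acceptors and the net charge stay the same. For the compounds shown here, the earlier compounds offered no measured pair that isolated a single change, so this step is the first direct measure of what one edit does here, and it shows that a ring-size change at this position cannot be treated as negligible. The same swap also moves a second, quite different read-out in a physicochemical assay for solubility, measured as kinetic solubility (on this read-out lower numbers stand for lower solubility and higher numbers for higher solubility), where compound 1 gives 1.3 ug/mL and compound 4 gives 12 ug/mL: the measured solubility of compound 1, 1.3 ug/mL, and of compound 4, 12 ug/mL, a 9.2-fold higher number (0.97 log units; beyond the scatter)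

With only these two ring sizes, the compounds shown leave open whether the free fraction keeps rising as the ring shrinks further, to azetidine, or whether it depends on ring size at all rather than on the particular ring, a question that morpholine, with an oxygen in the ring, would also bear on. They also leave open whether the rises in free fraction and solubility are linked or merely happen together in this one pair.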